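Ethyl to (tert-butyl)carbonyl on the ring amine nitrogen

The source may hold more compounds than are shown below. What is called first, only, known or untested is meant among the compounds shown, and "the series" means these compounds.

Measured in an assay for inhibition of tyrosine-protein kinase receptor UFO (Homo sapiens), read by 33P incorporation, in the presence of a further agent that is not named here; a higher number here means a weaker inhibitor, a lower number a stronger inhibitor:
- compound 1, `CCN1CCN(c2ccc(-c3nn(Cc4cn(Cc5ccccc5)nn4)c4nc(NC)ncc34)cn2)CC1`: compound 1 gives > 10000 nM, a limit of the assay.
- compound 2, `CNc1ncc2c(-c3ccc(N4CCN(C(=O)C(C)(C)C)CC4)nc3)nn(Cc3cn(Cc4ccccc4)nn3)c2n1`: compound 2 gives 760 nM.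
- compound 3, `CCN1CCN(c2ccc(-c3nn(CC4CCCC4)c4nc(NC)ncc34)cn2)CC1`: compound 3 gives 260 nM.

The change (tert-butyl)carbonyl in place of ethyl on an amine nitrogen in a ring gave an at least 13-fold lower number from compound 1 to compound 2 (1.11 log units; beyond the scatter). That step rests on (the limit of > 10000 nM in this assay, at which 1 of the 3 values shown sits), so its true size is not known beyond the stated bound. The cores of compound 1 and compound 3 differ by cyclopentyl in place of 1-benzyl-1H-1,2,3-triazol-4-yl on a saturated chain carbon bound to an aromatic nitrogen, which gave an at least 38-fold lower number from compound 1 to compound 3 (1.58 log units; beyond the scatter).

Compound 4, `CNc1ncc2c(-c3ccc(N4CCN(C(=O)C(C)(C)C)CC4)nc3)nn(CC3CCCC3)c2n1`, is not yet measured. It carries the same change on the core of compound 3: (tert-butyl)carbonyl in place of ethyl on an amine nitrogen in a ring, with the place described in the same words as before. Because the reference step is bounded only by the limit of > 10000 nM in this assay, at which 1 of the 3 values shown sits, a smaller step is expected here: a 2.9-fold lower number from compound 3 to compound 4 (0.46 log units; beyond the scatter). Compound 4 is estimated at 90 nM, with a range from 30 nM to 300 nM.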

Compound 4, half-maximal inhibitory concentration: 7200 nM
For compound 4 the middle estimate is 80-fold (1.90 log units) below the measured one; the measured number lies above the stated range.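

In this assay, (tert-butyl)carbonyl in place of ethyl on the core of compound 3 gives a 28-fold higher number from compound 3 to compound 4 (1.44 log units; beyond the scatter), opposite in direction to the step on the other core: the same change on two cores in this assay, an at least 13-fold lower number (1.11 log units; beyond the scatter) from compound 1 to compound 2 and a 28-fold higher number (1.44 log units; beyond the scatter) from compound 3 to compound 4, at least 360-fold (2.56 log units) apart, beyond the scatter of two such steps. Cyclopentyl in place of 1-benzyl-1H-1,2,3-triazol-4-yl, with (tert-butyl)carbonyl on the amine nitrogen in a ring, gives a 9.5-fold higher number from compound 2 to compound 4 (0.98 log units; beyond the scatter), so this change too does not carry over: the same change on two cores in this assay, an at least 38-fold lower number (1.58 log units; beyond the scatter) from compound 1 to compound 3 and a 9.5-fold higher number (0.98 log units; beyond the scatter) from compound 2 to compound 4, at least 360-fold (2.56 log units) apart, beyond the scatter of two such steps. The two changes therefore do not add up across these four compounds, but the data do not show why, and the gaps remain bounds, as compound 1 stands at a limit of the assay: the limit of > 10000 nM in this assay, at which 1 of the 4 values shown sits.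

From the compounds shown here alone, it remains open whether the reversal holds for an acetyl or a methyl on the amine nitrogen in a ring. The same question stands for a cyclohexyl on the saturated chain carbon bound to an aromatic nitrogen.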